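Shortening the phenyl-tipped chain of compound 1

The source may report more compounds than this note shows. Statements on the series, on what has been measured and on what is new or still open speak of the compounds shown alone.

- compound 1 `O=C(CCCCCCCCCCCc1ccccc1)CC(=O)N[C@H]1CCOC1=O`: 33000 nM
- compound 2 `O=C(CCCCCc1ccccc1)CC(=O)N[C@H]1CCOC1=O`: 44000 nM
- compound 3 `O=C(CCCCCCCCCc1ccccc1)CC(=O)N[C@@H]1CCOC1=O`: > 100000 nM

In a functional assay on NCI-H630 cells (Homo sapiens) for cytotoxicity, read by sulforhodamine B assay, with a stated time of 5 days (on this read-out higher numbers stand for weaker inhibition and lower numbers for stronger inhibition), compound 1 gives 33000 nM and compound 2 gives 44000 nM. Among the compounds with values here, these are the only two exact numbers in the set, and they lie within the usual scatter of each other, so neither can be ranked ahead. For compound 3 the entry > 100000 nM is a limit of the assay and not a number.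

Compound 4 `O=C(CCCCCCCCc1ccccc1)CC(=O)N[C@H]1CCOC1=O` has not yet been measured. Its structure departs from that of compound 1 by one change: phenyl in place of 3-phenylpropyl on a saturated chain carbon, eight bonds along the chain from a carbonyl carbon.

Within the data shown here, no measured pair in the set differs in one place only, so no direct step is available as a guide. The expectation rests on compound 1 at 33000 nM and compound 2 at 44000 nM, and no step beyond the scatter is expected in this assay. The expected change is a 1.2-fold higher number from compound 1 to compound 4 (0.08 log units; within the scatter). A reading that is only a limit remains possible. Compound 4 is estimated at 40000 nM, with an expected range of 15000 nM to 100000 nM.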

Compound 4, half-maximal inhibitory concentration: 11000 nM
For compound 4 the middle estimate is 3.6-fold (0.56 log units) above the measured one; measured number below the stated range.
By their numbers in this assay, from the lowest: compound 4; then compounds 1 and 2 (each within the scatter of the next). At a limit, above all of these: compound 3.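

In this assay, within the data shown here, replacing 3-phenylpropyl with phenyl on a saturated chain carbon, eight bonds along the chain from a carbonyl carbon, gives a 3.0-fold lower number from compound 1 to compound 4 (0.48 log units; beyond the scatter) and so provides the first single-place change in the set, showing that this position responds to the change by more than the scatter. Compound 2, whose phenyl-tipped chain is shorter still, gives 44000 nM in this assay, so the compounds shown do not support a steady gain as the chain is shortened, and the lower number of compound 4 remains a single observation at this chain length. The data shown offer nothing that explains why this step occurs.

As far as these compounds go, it remains open whether a chain one carbon longer or shorter than that of compound 4 would retain the lower number, and whether an amine or a carboxylic acid in place of the terminal phenyl would be tolerated. From the compounds shown here alone, compound 3 gives > 100000 nM, which is a limit of the assay, and because it differs from compound 4 in more than one place, the effect of the stereocentre alone also remains open.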